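Nitro in place of hydroxy: notes on compound 4

The source may report more compounds than this note shows. Statements on the series, on what has been measured and on what is new or still open speak of the compounds shown alone.

Measured compounds, all in a functional assay on HeLa cells (Homo sapiens) for antiproliferative activity, read by sulforhodamine B assay, with a stated time of 48 h (on this read-out lower numbers stand for stronger inhibition and higher numbers for weaker inhibition), as follows
- compound 1 `COc1ccc(C(=O)/C=C\Nc2ccc(-c3nc4cc(OC)c(OC)c(OC)c4s3)cc2C)cc1[N+](=O)[O-]` gives 13400 nM
- compound 2 `COc1cc(OC)c2sc(-c3ccc(N/C=C\C(=O)c4ccc(OC)c([N+](=O)[O-])c4)cc3)nc2c1` gives 12900 nM
- compound 3 `COc1ccc(C(=O)/C=C\Nc2ccc(-c3nc4cc(OC)c(OC)c(OC)c4s3)cc2)cc1O` gives 14100 nM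

The three values lie within the scatter of one another, so compound 3 at 14100 nM is not separated from compound 1 or compound 2 in this assay by these numbers. The next compound to be measured is compound 4 `COc1ccc(C(=O)/C=C\Nc2ccc(-c3nc4cc(OC)c(OC)c(OC)c4s3)cc2)cc1[N+](=O)[O-]` and it has nitro in place of hydroxy on an aromatic carbon, ortho to a methoxy group nitro in place of hydroxy on an aromatic carbon so that 3-hydroxy-4-methoxyphenyl becomes 4-methoxy-3-nitrophenyl. For the measured compounds named here, no measured pair isolates this change. The 4-methoxy-3-nitrophenyl group is already present in compound 1, at 13400 nM and in compound 2, at 12900 nM and neither value stands apart from that of compound 3. On that basis, no change beyond the scatter is expected, and the estimated move is a 1.2-fold lower number from compound 3 to compound 4 (0.07 log units; within the scatter) in this series. For compound 4 the estimated value is 12000 nM with an expected range from 5000 nM to 28000 nM in this assay when measured.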

Compound 4, half-maximal inhibitory concentration: 11400 nM
Compound 4: middle estimate off by 1.1-fold (0.02 log units), on the high side; low and high end bracket the measured number.
By their numbers in this assay, from the lowest: compounds 4, 2, 1 and 3 (each within the scatter of the next).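

In this assay, the change of hydroxy to nitro on this aromatic carbon, ortho to a methoxy group, can now be read directly as a 1.2-fold lower number from compound 3 to compound 4 (0.09 log units; within the scatter) and so does not separate the two groups. With the 4-methoxy-3-nitrophenyl group held constant, the two changes elsewhere can also be read: methoxy in place of hydrogen on an aromatic carbon gives a 1.1-fold lower number from compound 2 to compound 4 (0.05 log units; within the scatter) and hydrogen in place of methyl on an aromatic carbon gives a 1.2-fold lower number from compound 1 to compound 4 (0.07 log units; within the scatter), so neither step separates its pair. Nothing measured here bears on why these steps stay so small.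

The compounds shown leave open whether an amine or a carboxylic acid on this aromatic carbon would give a number beyond the scatter of these values. They also leave open how this position reads when the neighbouring methoxy group is replaced by a longer alkoxy chain.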